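A few compounds are considered here, and "the series" means these few. Any claim that something is new, unique, unknown or untested is made for them only; others in the source may bear on it.

In a functional assay on cells (Splenocyte, Mus musculus, strain BALB/c) for inhibition, read by scintillation counting and thymidine incorporation, with a stated time of 72 h (a higher number here means a weaker inhibitor, a lower number a stronger inhibitor), three compounds have been examined so far. Compound 2 `CC(/C=N/Nc1ccc([N+](=O)[O-])cc1)=N\NC(=O)c1ccc(C(C)(C)C)cc1` gives > 12000 nM, which is a limit of the assay rather than a number. Compound 3 `CC(/C=N/N(C)c1ccc([N+](=O)[O-])cc1)=N\NC(=O)c1ccc(N)cc1` likewise gives > 12000 nM, again a limit. Compound 1 `CC(/C=N/Nc1ccc([N+](=O)[O-])cc1)=N\NC(=O)c1ccccc1Nc1ccccc1` gives "not determined" (no result reported), so no result exists for it. Compound 2 therefore stands only at a limit, and it shares that position with the limit of > 12000 nM in this assay, at which 2 of the 3 values shown sit, which leaves nothing to rank it against.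

Compound 4 `CC(/C=N/Nc1ccc([N+](=O)[O-])cc1)=N\NC(=O)c1ccc(Cl)cc1` differs from compound 2 by a single change: chloro in place of tert-butyl on an aromatic carbon. No pair of measured compounds shows the effect of this change, so the size of the step in this assay cannot be read from the numbers shown. With compound 2 sitting at a limit, the expected step from compound 2 to compound 4 is a step that the limit leaves unreadable from compound 2 to compound 4, that is, no shift beyond the usual scatter in either direction. Compound 4 is accordingly estimated at 15000 nM, with a range from 4000 nM to 60000 nM, and it is quite possible that the assay will again report only a limit.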

Compound 4, half-maximal inhibitory concentration: 4200 nM
The estimate for compound 4 lay 3.6-fold (0.55 log units) above the measured number; the measured number falls inside the stated range.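

In this assay, chloro in place of tert-butyl on the aromatic carbon gives an at least 2.8-fold lower number from compound 2 to compound 4 (0.45 log units; beyond the scatter). Compound 4 is the only compound shown with a measured number rather than a limit or no result, so this position can clearly alter the read-out, and further changes to compound 4 can be compared with a real value. This step is only a minimum, since compound 2 carries a limit and not a number, and its true value is unknown: the limit of > 12000 nM in this assay, at which 2 of the 4 values shown sit.

A single pair cannot separate a benefit of chloro itself from the loss of tert-butyl. On these data alone, how fluoro, bromo or methoxy would behave at this place remains open, as does whether a still smaller or a differently built group would lower the number further.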